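A few compounds are considered here, and "the series" means these few. Any claim that something is new, unique, unknown or untested is made for them only; others in the source may bear on it.

Measured compounds:
compound 1 `CC(C)(C)c1cc(/C=C/C(=O)NCCC2CCN(Cc3ccc(F)cc3F)CC2)cc(C(C)(C)C)c1O` with 70600 nM
compound 2 `CC(C)(C)c1cc(/C=C/C(=O)NCCC2CCN(Cc3ccc(Br)cc3)CC2)cc(C(C)(C)C)c1O` with 73200 nM

Both compounds share a core and differ only in the group on the benzyl carbon of the ring amine. In an assay on isolated protein for inhibition of Amine oxidase [flavin-containing] A (Homo sapiens), read by fluorescence, with stated times of 15 min and 20 min (on this read-out lower numbers stand for stronger inhibition and higher numbers for weaker inhibition), compound 1 gives 70600 nM, and compound 2 gives 73200 nM. Compound 2 stands with the highest of the two numbers, though the step of a 1.0-fold higher number from compound 1 to compound 2 (0.02 log units; within the scatter) is within the scatter, so the two cannot be ordered.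

Compound 3 `CC(C)(C)c1cc(/C=C/C(=O)NCCC2CCN(Cc3ccc(C#N)cc3)CC2)cc(C(C)(C)C)c1O` is not yet measured. Its change from compound 2 is cyano in place of bromo on an aromatic carbon, on an aromatic carbon of a six-membered aromatic ring of carbon only, para to a large group; cut one bond further out it reads 4-bromophenyl to 4-cyanophenyl.

Within the data shown here, only one measured step bears on this position: a 1.0-fold higher number from compound 1 to compound 2 (0.02 log units; within the scatter), which shows that exchanging 2,4-difluorophenyl for 4-bromophenyl left this assay unchanged beyond the scatter. On that basis the step from compound 2 to compound 3 is expected to be small, estimated as a 1.1-fold higher number from compound 2 to compound 3 (0.04 log units; within the scatter), in no reliable direction. Compound 3 is therefore expected to give about 80000 nM, within a range of 30000 nM to 200000 nM.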

Compound 3, half-maximal inhibitory concentration: 78200 nM
For compound 3 the middle estimate is 1.0-fold (0.01 log units) above the measured one; the range from low to high includes it.
By their numbers in this assay, from the lowest: compounds 1, 2 and 3 (each within the scatter of the next).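

In this assay, the earlier pair changed the number and the placing of the halogens together, whereas here a single group on an aromatic carbon, para to a large group, is exchanged on its own. Cyano, with two heavy atoms and one hydrogen-bond acceptor, replaces bromo, with one heavy atom and no acceptor, and the outcome is a 1.1-fold higher number from compound 2 to compound 3 (0.03 log units; within the scatter), so this difference in atoms and acceptor count does not separate the two compounds in this assay. The comparison with the difluorinated compound reads the same, at a 1.1-fold higher number from compound 1 to compound 3 (0.04 log units; within the scatter), and so 2,4-difluorophenyl, 4-bromophenyl and 4-cyanophenyl all lie within the scatter of one another, which extends the earlier finding from halogens to a nitrile.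

No evidence is given that could account for how closely these values lie together. From the compounds shown here alone, it remains open whether an amine or a carboxylic acid on this aromatic carbon, or a longer chain in place of the benzyl carbon, would shift the number beyond the scatter, or whether this part of the molecule leaves the read-out unchanged whatever it carries.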